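Replacing the 3-methyl-1,2-oxazol-5-yl group of compound 1

The source may hold more compounds than are shown below. What is called first, only, known or untested is meant among the compounds shown, and "the series" means these compounds.

Compound 1 `COc1ccc(/C=C/c2cc(C)no2)cc1OC` reads > 100000 nM as a limit
Compound 2 `COc1ccc(/C=C/c2cc(C)no2)cc1` reads > 100000 nM as a limit

In a functional assay on DU-145 cells (Homo sapiens) for cytotoxicity, read by MTT assay, with a stated time of 72 h (a lower number here means a stronger inhibitor, a higher number a weaker inhibitor), compound 1 stands at > 100000 nM and that is a limit, not a number. Neither measured compound has left that limit (the limit of > 100000 nM in this assay, at which 2 of the 2 values shown sit) so far. Compound 3 `COc1ccc(/C=C/c2cc(C)n[nH]2)cc1OC` differs from compound 1 at a single place (3-methyl-1H-pyrazol-5-yl in place of 3-methyl-1,2-oxazol-5-yl on a double-bonded chain carbon bound to a double-bonded chain carbon) on the shared core. Going by the values given here, the only measured step (a step that the two limits leave unreadable from compound 1 to compound 2) concerns a different change and offers no size to carry over. With no readable step to go on, only a modest move toward a stronger inhibitor is expected in this assay and compound 3 may well remain at the limit. The estimated step is an at least 1.6-fold lower number from compound 1 to compound 3 (0.22 log units; that floor lies within the scatter) and it remains highly uncertain. Compound 3 is estimated at 60000 nM with 15000 nM and 100000 nM as the ends of its expected range.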

Compound 3, half-maximal inhibitory concentration: 18500 nM
Compound 3: the middle estimate sits 3.2-fold (0.51 log units) above what was measured; the measured number falls inside the stated range.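

In this assay compound 1 reads > 100000 nM, which is a limit and not a number. Placing 3-methyl-1H-pyrazol-5-yl in place of 3-methyl-1,2-oxazol-5-yl on this double-bonded chain carbon gives an at least 5.4-fold lower number from compound 1 to compound 3 (0.73 log units; beyond the scatter), so this position, unlike the methoxy change, yields a readable response. Compound 3 is the only compound shown to have left the limit, so it alone has a measured number, and the size of the step remains a floor: the limit of > 100000 nM in this assay, at which 2 of the 3 values shown sit.

On these data alone, the step from compound 1 to compound 2 cannot be read, so whether the methoxy groups matter once the 3-methyl-1H-pyrazol-5-yl group is present remains open. Also open, as far as these compounds go, is how an amine or a longer chain in place of the methyl on that group would read.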